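A few compounds are considered here, and "the series" means these few. Any claim that something is new, unique, unknown or untested is made for them only; others in the source may bear on it.

Measured so far in a functional assay on HepG2 cells (Homo sapiens) for antiproliferative activity, read by MTT assay, with a stated time of 48 h; on this read-out higher numbers stand for weaker inhibition of growth and lower numbers for stronger inhibition of growth 
- compound 1 `Cc1ccc(-c2cnc(N(Cc3ccccc3)Cc3ccc(C(=O)NO)cc3)s2)cc1` gives 34000 nM 
- compound 2 `CCCCCCCCN(Cc1ccc(C(=O)NO)cc1)c1ncc(-c2ccc(C)cc2)s1` gives 8760 nM 
- compound 3 `Cc1ccc(OCCCCN(Cc2ccc(C(=O)NO)cc2)c2ncc(-c3ccc(C)cc3)s2)cc1` gives 11000 nM 

Compound 3 stands with compound 2, the gap being a 1.3-fold higher number from compound 2 to compound 3 (0.10 log units; within the scatter), and apart from compound 1, the gap being a 3.1-fold lower number from compound 1 to compound 3 (0.49 log units; beyond the scatter). Compound 4 `CCCCN(Cc1ccc(C(=O)NO)cc1)c1ncc(-c2ccc(C)cc2)s1` arises through (hydrogen in place of 4-methylphenoxy on a saturated chain carbon, four bonds along the chain from a nitrogen on an aromatic ring), that is, hydrogen in place of 4-methylphenoxy on a saturated chain carbon, four bonds along the chain from a nitrogen on an aromatic ring. The nearest measured change at this carbon is a 1.3-fold higher number from compound 2 to compound 3 (0.10 log units; within the scatter). The steps of a 3.9-fold lower number from compound 1 to compound 2 (0.59 log units; beyond the scatter) and a 3.1-fold lower number from compound 1 to compound 3 (0.49 log units; beyond the scatter) were modest and start from phenyl, so they bear less closely. No step beyond the scatter is expected in this assay, the estimate being a 1.2-fold higher number from compound 3 to compound 4 (0.07 log units; within the scatter). Compound 4 is estimated at 13000 nM, with an expected range of 6000 nM to 28000 nM.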

Compound 4, concentration for 50% growth inhibition: 4300 nM
The estimate for compound 4 lay 3.0-fold (0.48 log units) above the measured number; the whole stated range lies above it.
By their numbers in this assay, from the lowest: compound 4; then compounds 2 and 3 (each within the scatter of the next); then compound 1.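

In this assay, hydrogen in place of 4-methylphenoxy on this chain carbon gives a 2.6-fold lower number from compound 3 to compound 4 (0.41 log units; beyond the scatter) and hydrogen in place of butyl gives a 2.0-fold lower number from compound 2 to compound 4 (0.31 log units; beyond the scatter) at the same place, so the number at this position does move, although compound 2 and compound 3 had stayed within the scatter of each other. With propyl in place of phenyl, the step reaches a 7.9-fold lower number from compound 1 to compound 4 (0.90 log units; beyond the scatter) in the same assay. No evidence on the cause of these steps is available. On these data alone, whether a shorter chain, or an amine or carboxylic acid at the chain end, would lower the number further remains open.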